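This account rests on a few compounds, and the source may have more. Where it says the series, first, only, none or still open, it means among the compounds named here.

Measured in a functional assay on KB cells (Homo sapiens) for antiproliferative activity, read by sulforhodamine B assay, with a stated time of 3 days; on this read-out higher numbers stand for an effect only at larger amounts of compound and lower numbers for an effect already at smaller amounts:
compound 1 `CCCC1=C(OC)C(CCC)(CCC)C(=O)/C(=C(O)\C=C\c2ccc(I)cc2)C1=O`: 1.5 uM
compound 2 `CCCC1=C(OC)C(CCC)(CCC)C(=O)/C(=C(O)\C=C\c2ccc(Br)cc2)C1=O`: 1.8 uM
compound 3 `COC1=C(CC=C(C)C)C(=O)/C(=C(O)/C=C/c2ccccc2)C(=O)C1(CC=C(C)C)CC=C(C)C`: 13.3 uM

Compound 1 sits with compound 2 at the low end of these numbers, the two within the scatter of each other, and compound 3 stands well apart at the high end. Compound 4 `CCCOC1=C(CCC)C(=O)/C(=C(O)/C=C/c2ccc(I)cc2)C(=O)C1(CCC)CCC` keeps the core of compound 1 and turns methoxy into propoxy: ethyl in place of hydrogen on a saturated chain carbon bound to an oxygen on an unsaturated carbon. Going by the values given here, the one measured single-place step, a 1.2-fold higher number from compound 1 to compound 2 (0.08 log units; within the scatter), is a halogen exchange on an aromatic carbon and stays within the scatter. Among the compounds with values here, it bears only indirectly, and no measured step covers this ether chain. Compound 3 differs from compound 1 in several places, so its gap cannot be assigned to any one change. No shift beyond the scatter is therefore expected in this assay, and the expected step is a 1.2-fold higher number from compound 1 to compound 4 (0.08 log units; within the scatter). Compound 4 is estimated at 1.8 uM, with an expected range of 0.7 uM to 5 uM.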

Compound 4, concentration for half-maximal effect: 6.4 uM
Estimate against measurement, compound 4: 3.6-fold (0.55 log units) below; measured number outside the range, above it.
By their numbers in this assay, from the lowest: compounds 1 and 2 (each within the scatter of the next); then compound 4; then compound 3.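

In this assay, going by these compounds alone, the ether chain proves to be a position that responds: methoxy to propoxy gives a 4.3-fold higher number from compound 1 to compound 4 (0.63 log units; beyond the scatter), whereas the only earlier single-place step, the halogen exchange, stayed within the scatter. Within the data shown here, at this position, ethyl in place of hydrogen therefore costs potency, though only one such step is available. Nothing measured here accounts for the shift.

Going by these compounds, whether ethoxy falls between methoxy and propoxy, or a longer chain such as hexyloxy moves the number further, remains open. On these data alone, the effect of this change with bromo on the aromatic ring also remains open.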